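Swapping a Furan for a Methylphenyl on a Weak Growth Inhibitor

This account rests on a few compounds, and the source may have more. Where it says the series, first, only, none or still open, it means among the compounds named here.

Of the compounds shown here, two have been tested so far. Compound 1 `N#C/C(=C\c1ccc([N+](=O)[O-])cc1)C(=O)c1c[nH]c2ccccc12` gives 48000 nM in a functional assay on A2780 cells (Homo sapiens) for inhibition, read by MTT assay, with a stated time of 72 h; a lower number here means a stronger inhibitor of growth, a higher number a weaker inhibitor of growth. Compound 2 `COc1ccc(CNC(=O)/C(C#N)=C/c2ccco2)cc1` gives 24000 nM in the same assay. The gap between these two numbers lies within the scatter of repeated measurements, so compound 2 and compound 1 cannot be told apart on this evidence: both are weak inhibitors of growth.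

Compound 3 `COc1ccc(CNC(=O)/C(C#N)=C/c2ccc(C)cc2)cc1` is the next candidate. It differs from compound 2 in one place: 4-methylphenyl in place of furan-2-yl on a double-bonded chain carbon bound to a double-bonded chain carbon. Going by the values given here, no measured pair shows what this kind of change does here, so there is no step to lean on. The expectation is that compound 3 stays a weak inhibitor, with the step of a 1.3-fold higher number from compound 2 to compound 3 (0.10 log units; within the scatter) expected to be no larger than the scatter in either direction. Compound 3 is therefore estimated at 30000 nM in this assay, within a range from 10000 nM to 90000 nM.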

Compound 3, concentration for 50% growth inhibition: 33000 nM
Compound 3: the middle estimate sits 1.1-fold (0.04 log units) below what was measured; measured number inside the range.
By their numbers in this assay, from the lowest: compounds 2, 3 and 1 (each within the scatter of the next).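

In this assay, putting 4-methylphenyl in place of furan-2-yl on a double-bonded chain carbon bound to a double-bonded chain carbon gives a 1.4-fold higher number from compound 2 to compound 3 (0.14 log units; within the scatter), so this exchange does not produce a change that can be told apart from scatter. Going by these compounds alone, this is the first evidence about this position: a five-membered aromatic ring with a hetero atom and a six-membered aromatic ring of carbon only give readings that cannot be separated here, and both compounds remain weak inhibitors of growth. No measurement shown here offers an explanation for this result.

From the compounds shown here alone, what a non-aromatic group, such as a cyclohexyl ring or a chain ending in an amine, would do at this position remains open. So does whether any group placed here could move the number beyond the scatter.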